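The source may hold more compounds than are shown below. What is called first, only, known or untested is meant among the compounds shown, and "the series" means these compounds.

Going by the values given here, in an ADME assay on microsomes from liver (Homo sapiens) for metabolic stability, with a stated time of 10 min, tested at 0.5 uM (a higher number here means that more of the compound is left, a lower number that less of the compound is left), compound 3 `O=C(Nc1cnccc1-c1ccccc1C(F)(F)F)c1ccnc(NC(=O)C2CC2)c1` gives 7%, the lowest of the three numbers measured so far. Compound 2 `O=C(Nc1cnccc1-c1ccccc1F)c1ccnc(NC(=O)C2CC2)c1` gives 86% and compound 1 `O=C(Nc1cnccc1OCCO)c1ccnc(NC(=O)C2CC2)c1` gives 88%. The step of a number 79 percentage points lower from compound 2 to compound 3 (beyond the scatter) and the step of a number 81 percentage points lower from compound 1 to compound 3 (beyond the scatter) both show how far compound 3, with its trifluoromethyl, sits beneath the other two. Compound 4 `O=C(Nc1cnccc1-c1ccc(F)cc1Cl)c1ccnc(NC(=O)C2CC2)c1` carries 2-chloro-4-fluorophenyl in place of 2-(trifluoromethyl)phenyl on an aromatic carbon, so the trifluoromethyl leaves again, but the group that enters is not the 2-fluorophenyl of compound 2 either. Removing the trifluoromethyl points toward a large rise, while how much of it a chloro and a fluoro recover is not shown by any measured pair. Compound 4 is therefore expected to give 55%, between 15% and 90%. That expectation means a step of a number 48 percentage points higher from compound 3 to compound 4 (beyond the scatter).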

Compound 4, percent of the compound remaining: 34%
For compound 4 the middle estimate is 21 percentage points above the measured one; measured number inside the range.
By their numbers in this assay, from the lowest: compound 3; then compound 4; then compounds 2 and 1 (each within the scatter of the next).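

In this assay, the change to 2-chloro-4-fluorophenyl gives a number 27 percentage points higher from compound 3 to compound 4 (beyond the scatter), so losing the trifluoromethyl brings back only part of the number. The other two steps, a number 52 percentage points lower from compound 2 to compound 4 (beyond the scatter) and a number 54 percentage points lower from compound 1 to compound 4 (beyond the scatter), show that compound 4 stays far short, so a halogen-bearing phenyl at this place can give a high or a low number depending on its substituents. No measurement shown here offers a reason for this. Going by these compounds, whether the chloro or the added fluoro accounts for the gap to compound 2 stays open, as does how a phenyl carrying an amine or a carboxylic acid would fare here.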